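Replacing Chloro with Hydroxy: What Response to Expect

The source may report more compounds than this note shows. Statements on the series, on what has been measured and on what is new or still open speak of the compounds shown alone.

Of the compounds shown here, three built on a shared core have been tested in a functional assay on CHO cells for agonist activity at Free fatty acid receptor 1 (Homo sapiens), read by reporter gene assay; on this read-out higher numbers stand for larger maximal responses and lower numbers for smaller maximal responses. Compound 1 `O=C(O)CCc1ccc(NCc2ccc(Cl)cc2)cc1` gives 111% in this assay. Compound 3 `O=C(O)CCc1ccc(NCc2ccc(Cl)c(Cl)c2)cc1` gives 117%, and the change from one to the other is a number 6 percentage points higher from compound 1 to compound 3 (within the scatter). Compound 2 `O=C(O)CCc1cccc(NCc2ccc(-c3ccccc3)cc2)c1` gives 160%. On these numbers compound 1 stands lowest of the three: its nearest neighbour is compound 3, a difference that lies within the scatter, while compound 2 lies furthest away, beyond the scatter.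

Compound 4 `O=C(O)CCc1ccc(NCc2ccc(O)cc2)cc1` has not yet been measured. It differs from compound 1 in one place: hydroxy in place of chloro on an aromatic carbon. Going by the values given here, the one measured step that touches the same ring, a number 6 percentage points higher from compound 1 to compound 3 (within the scatter), added a chloro to a position that held hydrogen and did not move the response beyond the scatter. Among the compounds with values here, no measured step removes a chloro or introduces a hydroxy, so there is no direct precedent for the exchange made here. Within the data shown here, with the only nearby step staying flat, the expectation for compound 4 in this assay is a response close to that of compound 1, with no shift beyond the scatter: an estimated step of a number 6 percentage points lower from compound 1 to compound 4 (within the scatter). Compound 4 is therefore estimated at 105%, expected to fall between 85% and 125%.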

Compound 4, largest response reached (reported as percent of maximum), in percent of the reference or control that the assay uses: 37%
Estimate against measurement, compound 4: 68 percentage points above; measured number outside the range, below it.
By their numbers in this assay, from the lowest: compound 4; then compounds 1 and 3 (each within the scatter of the next); then compound 2.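

Going by these compounds alone, this carbon, on a six-membered aromatic ring and para to a large group, is not as forgiving as the earlier compounds suggested: in this assay, hydroxy in place of chloro gives a number 74 percentage points lower from compound 1 to compound 4 (beyond the scatter), whereas the only earlier step on this ring, a number 6 percentage points higher from compound 1 to compound 3 (within the scatter), stayed within the scatter. The exchange is small by simple counting, with one heavy atom leaving and one entering, no ring involved and no net charge on either group, and the one listed gain is the hydrogen-bond donor and hydrogen-bond acceptor that hydroxy has and chloro lacks. So a single-atom exchange at this carbon can change the maximal response far more than the earlier step did, but nothing measured here shows which difference between the two groups is responsible.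

The compounds shown leave open whether a methoxy, an amine or a fluoro on this same carbon would stay close to compound 1 or fall towards compound 4. They also leave open whether hydroxy in place of the same chloro in compound 3 would produce a step of similar size.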